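The compounds below may be only part of what the source reports. "The series", "measured", "known", "first", "only" and "open" are said of these compounds alone.

Measured so far in a functional assay on K562 cells (Homo sapiens) for inhibition; a lower number here means a stronger inhibitor, a higher number a weaker inhibitor:
- Compound 1 `CNc1ncnc2c1ncn2C1O[C@H](CO)[C@@](C)(O)[C@H]1O`: 93800 nM
- Compound 2 `C[C@@]1(n2cnc3c(N)ncnc32)O[C@H](CO)[C@@H](O)[C@H]1O`: > 100000 nM, a limit of the assay
- Compound 3 `CNc1ncnc2c1ncn2C1O[C@H](CO)[C@@H](O)[C@@]1(C)O`: > 100000 nM, a limit of the assay

Compound 3 therefore has no exact number, only the limit > 100000 nM. It shares this position with compound 2, and the overall picture is the limit of > 100000 nM in this assay, at which 2 of the 3 values shown sit. For the measured compounds named here, compound 1 is the only one with an exact reading, at 93800 nM.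

Compound 4 `C[C@]1(O)C(n2cnc3c(NC4CC4)ncnc32)O[C@H](CO)[C@H]1O` is the next to be tested in this assay. It differs from compound 3 by one change, methylamino to cyclopropylamino: cyclopropyl in place of methyl on a nitrogen on an aromatic ring.

Going by the values given here, no measured pair of compounds shows what this change does, so the expectation is cautious: no step beyond the scatter in either direction. The estimated change a number no higher from compound 3 to compound 4 (the limit leaves the size open) is accordingly expected to be small. Among the compounds with values here, the only exact reading, from compound 1 at 93800 nM, suggests that weak inhibition is the likeliest outcome. For compound 4 the expected value is about 100000 nM, with an estimated range of 40000 nM to 250000 nM.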

Compound 4, half-maximal inhibitory concentration: > 100000 nM
Compound 4 ended at the assay's limit; the forecaster's own chance of this, stated with the estimate: 65%; the middle value sits exactly at the limit.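

In this assay compound 4 gives > 100000 nM, a limit of the assay. For the compounds shown here, compound 3 also stands at a limit, so no step between these two compounds can be read. What swapping methyl for cyclopropyl does to inhibition stays open, as most values shown share one limit: the limit of > 100000 nM in this assay, at which 3 of the 4 values shown sit.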